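The source may hold more compounds than are shown below. What is called first, only, known or untested is meant among the compounds shown, and "the series" means these compounds.

Compound 1 `O=C(COc1ccc2cc(/C=C3/SC(=O)NC3=O)ccc2c1)Nc1ccc(F)cc1` — 1600 nM
Compound 2 `O=C(COc1ccc2cc(/C=C3/SC(=O)NC3=O)ccc2c1)Nc1ccc(Cl)c(Cl)c1` — 5500 nM

In an assay on isolated protein for inhibition of histone deacetylase 4 (Homo sapiens), with a stated time of 1 h (on this read-out higher numbers stand for weaker inhibition and lower numbers for stronger inhibition), compound 2 gives 5500 nM, the highest of the two numbers; compound 1 sits a 3.4-fold higher number from compound 1 to compound 2 (0.54 log units; beyond the scatter) away. Compound 3 `COc1ccc(NC(=O)COc2ccc3cc(/C=C4/SC(=O)NC4=O)ccc3c2)cc1` differs from compound 2 by 4-methoxyphenyl in place of 3,4-dichlorophenyl on an amide-type nitrogen. Within the data shown here, the only step that bears on this is a 3.4-fold higher number from compound 1 to compound 2 (0.54 log units; beyond the scatter), where a single-substituted phenyl went to the dichlorinated one and the number rose. The reverse direction is therefore expected to lower the number modestly, with no direct evidence on methoxy itself. Compound 3 is expected at 2000 nM (range 700 nM to 6000 nM), a step of a 2.8-fold lower number from compound 2 to compound 3 (0.44 log units; beyond the scatter).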

Compound 3, half-maximal inhibitory concentration: 4700 nM
Estimate against measurement, compound 3: 2.4-fold (0.37 log units) below; the measured number falls inside the stated range.
By their numbers in this assay, from the lowest: compound 1; then compounds 3 and 2 (each within the scatter of the next).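

In this assay, 4-methoxyphenyl in place of 3,4-dichlorophenyl on the amide-type nitrogen gives (a 1.2-fold lower number from compound 2 to compound 3 (0.07 log units; within the scatter)), so the rise seen with the dichlorinated group is not confined to that group. Methoxy in place of fluoro on an aromatic carbon gives (a 2.9-fold higher number from compound 1 to compound 3 (0.47 log units; beyond the scatter)), leaving the 4-fluorophenyl of compound 1 as the only one of these three groups with a number lower beyond the scatter. No evidence on the cause of these differences is available.

As far as these compounds go, whether an unsubstituted phenyl or a single chloro would track compound 1 stays open. So does the effect of an amine or a carboxylic acid on this ring.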